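Trifluoromethyl in place of a six-atom group: series notes

The source may hold more compounds than are shown below. What is called first, only, known or untested is meant among the compounds shown, and "the series" means these compounds.

Compound 1 `CC(O)(CSc1ccc(S(F)(F)(F)(F)F)cc1)C(=O)Nc1ccc(S(F)(F)(F)(F)F)cc1` gives 22300 nM in a functional assay on DU-145 cells (Homo sapiens) for antiproliferative activity, read by propidium iodide staining, with a stated time of 96 h; on this read-out lower numbers stand for stronger inhibition and higher numbers for weaker inhibition. Compound 2 `CC(O)(CSc1ccc(C(F)(F)F)cc1)C(=O)Nc1ccc(S(F)(F)(F)(F)F)cc1` carries a group of 4 heavy atoms (1 carbon, 3 fluorine; no ring) in place of a group of 6 heavy atoms (5 fluorine, 1 sulfur; no ring), on an aromatic carbon relative to compound 1, and in this assay compound 2 gives 28800 nM; this change made a 1.3-fold higher number from compound 1 to compound 2 (0.11 log units; within the scatter). Compound 3 `CC(O)(COc1cccc(S(F)(F)(F)(F)F)c1)C(=O)Nc1ccc(S(F)(F)(F)(F)F)cc1` rests on a different core; the difference between the two cores is not broken down here. In this assay compound 3 gives 29600 nM, which sits within the scatter of both compound 1 and compound 2. Compound 4 `CC(O)(COc1cccc(S(F)(F)(F)(F)F)c1)C(=O)Nc1ccc(C(F)(F)F)cc1` is not yet measured and differs from compound 3 by a group of 4 heavy atoms (1 carbon, 3 fluorine; no ring) in place of a group of 6 heavy atoms (5 fluorine, 1 sulfur; no ring), on an aromatic carbon, the same change as from compound 1 to compound 2 at the same kind of place. Because this change earlier made a 1.3-fold higher number from compound 1 to compound 2 (0.11 log units; within the scatter), a step of similar size is expected from compound 3 to compound 4: a 1.2-fold higher number from compound 3 to compound 4 (0.07 log units; within the scatter). Compound 4 is therefore estimated at 35000 nM, with an expected range from 15000 nM to 80000 nM.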

Compound 4, half-maximal inhibitory concentration: 21000 nM
Compound 4: the middle estimate sits 1.7-fold (0.22 log units) above what was measured, and the stated range covers the measured number.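

Trifluoromethyl in place of the group of 6 heavy atoms in this assay gives a 1.4-fold lower number from compound 3 to compound 4 (0.15 log units; within the scatter) and so leaves the number within the scatter on this core, as on the core of compound 1. Set side by side, the two steps do not differ: the same change on two cores in this assay, a 1.3-fold higher number (0.11 log units; within the scatter) from compound 1 to compound 2 and a 1.4-fold lower number (0.15 log units; within the scatter) from compound 3 to compound 4, 1.8-fold (0.26 log units) apart, within the scatter of two such steps.
Going by these compounds alone, the change therefore carries between these two cores without a readable effect, but two pairs give no direction for the step and say nothing about any other core.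

Open, on these data alone, is whether a different kind of group in the same place, such as an amine, a carboxylic acid or a nitrile, would move the number beyond the scatter. Also open, as far as these compounds go, is whether the flat picture holds in any read-out other than this one.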